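Swapping the Hydroxyphenyl Group for a Methylphenyl Group

This account rests on a few compounds, and the source may have more. Where it says the series, first, only, none or still open, it means among the compounds named here.

Of the compounds shown here, three built on a shared core have been tested in an ADME assay on Vero cells (Chlorocebus sabaeus) for cytotoxicity, read by neutral red uptake, tested at 197 ug/mL; a lower number here means a stronger effect, a higher number a weaker effect of the compound at the concentration tested. Compound 1 `O=C1CSC(c2c(Cl)cccc2Cl)N1CCN1CCCCC1` gives 75%, and compound 3 `COc1ccccc1C1SCC(=O)N1CCN1CCCCC1` gives 72%. Compound 2 `O=C1CSC(c2cccc(O)c2)N1CCN1CCCCC1` gives 100%, the highest number of the three and therefore the weakest effect at the concentration tested; its gaps to compound 1 and to compound 3 both lie beyond the scatter.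

Compound 4 `Cc1ccc(C2SCC(=O)N2CCN2CCCCC2)cc1` has not yet been measured. It differs from compound 2 in a single place: 4-methylphenyl in place of 3-hydroxyphenyl on a saturated ring carbon. Among the measured compounds shown here, no step between measured compounds is known, so the size of this change is uncertain. A drop beyond the scatter is expected, a number 22 percentage points lower from compound 2 to compound 4 (beyond the scatter), which would bring the number toward those of compound 1 and compound 3. Compound 4 is estimated to give 78%, with a range from 60% to 100%.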

Compound 4, a percentage reported as activity, at one concentration (the size of the read-out at that concentration, not a potency): 85%
The estimate for compound 4 lay 7 percentage points below the measured number, within the range that was stated.
By their numbers in this assay, from the lowest: compounds 3, 1 and 4 (each within the scatter of the next, the first and the last beyond it); then compound 2.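

In this assay, this position now has its first step between two measured compounds: a number 15 percentage points lower from compound 2 to compound 4 (beyond the scatter), so exchanging 3-hydroxyphenyl for 4-methylphenyl on this saturated ring carbon moves the read-out modestly. The exchange alters both the group on the phenyl ring and where it sits, so these two differences cannot be separated here. Nothing available explains the step. The compounds shown leave open how 3-methylphenyl or 4-hydroxyphenyl would read, which would separate those two differences. From the compounds shown here alone, how an amine or a carboxylic acid on that phenyl ring would read also remains open.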